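A few compounds are considered here, and "the series" means these few. Any claim that something is new, unique, unknown or untested is made for them only; others in the source may bear on it.

Compound 1 `COc1ccc(-n2nc(Sc3ccc(Cl)cc3)cc(CC[C@@H](C)NC(=O)[C@H]3CNCC[C@@H]3c3ccc(Cl)cc3)c2=O)cc1` gives 2.4 nM in an assay on CHO cells for binding affinity to Melanocortin receptor 4 (Homo sapiens); on this read-out higher numbers stand for weaker inhibition and lower numbers for stronger inhibition.
Compound 2 `COc1ccc(-n2nc(Sc3ccc(Cl)cc3)cc(CC[C@@H](C)NC(=O)[C@H]3CNCC[C@@H]3c3ccc(Cl)cc3Cl)c2=O)cc1` gives 3.2 nM in this assay.
Compound 3 `COc1ccc(-n2nc(Sc3ccc(Cl)cc3)cc(CC[C@@H](C)NC(=O)[C@H]3CNCC[C@@H]3c3cccc(C(F)(F)F)c3)c2=O)cc1` gives 100 nM in this assay.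

Compound 3 stands highest of the three numbers, that is, it is the weakest binder of the set: one step up to it is a 31-fold higher number from compound 2 to compound 3 (1.49 log units; beyond the scatter), and the other is a 42-fold higher number from compound 1 to compound 3 (1.62 log units; beyond the scatter). Compound 1 and compound 2 themselves differ only by a 1.3-fold higher number from compound 1 to compound 2 (0.12 log units; within the scatter), a step that stays within the scatter.

Compound 4 `COc1ccc(-n2nc(Sc3ccc(Cl)cc3)cc(CC[C@@H](C)NC(=O)[C@H]3CNCC[C@@H]3c3ccc4ccccc4c3)c2=O)cc1` arises from compound 3 by a single change: naphthalen-2-yl in place of 3-(trifluoromethyl)phenyl on a saturated ring carbon. Both large measured steps bear on this position, since each exchanged a chlorinated phenyl group for the 3-(trifluoromethyl)phenyl group and raised the number sharply, so the aromatic group on this saturated ring carbon governs much of the outcome. Going by the values given here, no measured step involves a naphthalen-2-yl group, so its direction is not fixed by the data. Since compound 3 gave the weak 100 nM while the chlorinated phenyl analogues gave much lower numbers, compound 4 is expected to move part of the way back toward those values, by an estimated step of a 5.0-fold lower number from compound 3 to compound 4 (0.70 log units; beyond the scatter). The estimate for compound 4 is 20 nM, with an expected range from 4 nM to 100 nM.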

Compound 4, half-maximal inhibitory concentration: 17 nM
Beside the measured number, compound 4's estimate is 1.2-fold (0.07 log units) above it, and the stated range covers the measured number.
By their numbers in this assay, from the lowest: compounds 1 and 2 (each within the scatter of the next); then compound 4; then compound 3.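

In this assay, the step to naphthalen-2-yl, which keeps the count of heavy atoms but holds two six-membered aromatic rings of carbon only, gives a 5.9-fold lower number from compound 3 to compound 4 (0.77 log units; beyond the scatter), so a number well below that of compound 3 does not require a chlorinated phenyl group on this saturated ring carbon. The same group does not reach the chlorinated analogues, with a 5.3-fold higher number from compound 2 to compound 4 (0.73 log units; beyond the scatter) and a 7.1-fold higher number from compound 1 to compound 4 (0.85 log units; beyond the scatter), which places it in an intermediate tier: compounds 1 and 2 lie lowest, compound 4 lies beyond the scatter above them, and compound 3 lies beyond the scatter above compound 4. Nothing presented here accounts for this order.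

The compounds shown leave open how far the lower numbers depend on chlorine, since they give no reading for an unsubstituted phenyl group or a pyridine ring on this carbon. Going by these compounds, it also remains open whether the same order of aromatic groups would hold with a methyl group on the ring nitrogen.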